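A few compounds are considered here, and "the series" means these few. Any claim that something is new, unique, unknown or untested is made for them only; others in the source may bear on it.

Measured so far in an assay on membranes from HEK293 cells for displacement of a labelled ligand from adenosine receptor A2b (Homo sapiens), read by scintillation counting, with a stated time of 30 min; on this read-out higher numbers stand for weaker inhibition and lower numbers for stronger inhibition:
compound 1 `CCCOC(=O)C1=C(C)NC(=O)NC1c1ccoc1` gives 1190 nM
compound 2 `CC1=C(C(=O)OCc2ccccc2)C(c2cccs2)NC(=O)N1` gives 1920 nM
compound 3 `CC1=C(C(=O)C2CC2)C(c2ccco2)NC(=O)N1` gives 1060 nM

Compound 3 has the lowest of the three numbers in this assay, but its gaps to compound 1 and to compound 2 both sit within the scatter, so the three compounds read as one level. Compound 4 `CC1=C(C(=O)OCC2CCC2)C(c2ccco2)NC(=O)N1` is not yet measured. It differs from compound 3 by cyclobutylmethoxy in place of cyclopropyl on a carbonyl carbon. For the measured compounds named here, no pair of measured compounds differing in only one place bears on this change. Compound 1 and compound 2 carry other groups on that carbonyl carbon and give numbers close to compound 3, so no step beyond the scatter is expected for compound 4 in this assay, in either direction. The estimate for compound 4 is 1200 nM, range 500 nM to 3000 nM. The expected step of a 1.1-fold higher number from compound 3 to compound 4 (0.05 log units; within the scatter) is accordingly small.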

Compound 4, inhibition constant: 561 nM
Compound 4: middle estimate off by 2.1-fold (0.33 log units), on the high side; measured number inside the range.
By their numbers in this assay, from the lowest: compounds 4, 3, 1 and 2 (each within the scatter of the next, the first and the last beyond it).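

In this assay, for the compounds shown here, cyclobutylmethoxy in place of cyclopropyl on a carbonyl carbon gives a 1.9-fold lower number from compound 3 to compound 4 (0.28 log units; within the scatter), the first step that changes one place only. On this carbonyl carbon, the two groups therefore read as one level, even though cyclobutylmethoxy has more heavy atoms and a hydrogen-bond acceptor. No supporting data bear on this result.

Still open, from the compounds shown here alone, is whether an amine or a carboxylic acid on that carbonyl carbon would give a step beyond the scatter. Going by these compounds, a longer chain in place of cyclobutylmethoxy remains equally open.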